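The compounds below may be only part of what the source reports. "The series", "measured", "known", "first", "only" and "open" are said of these compounds alone.

In a functional assay on Vero cells (Chlorocebus sabaeus) for cytotoxicity (a higher number here means that more compound is tolerated, a lower number that less compound is tolerated), compound 3 `O=c1[nH]c(=O)n([C@H]2CO[C@@H](CO)S2)cc1/C=C/Br` gives 100 ug/mL, level with the other two measured compounds. Compound 1 `O=c1[nH]c(=O)n([C@H]2CO[C@H](CO)O2)cc1/C=C/Br` gives 100 ug/mL and compound 2 `O=c1[nH]c(=O)n([C@H]2CO[C@@H](CO)O2)cc1/C=C/Br` gives 100 ug/mL.

Compound 4 `O=c1[nH]c(=O)n([C@H]2CO[C@H](CO)S2)cc1/C=C/Br` is still unmeasured. Its difference from compound 3 is the two compounds have the same atoms and bonds and differ only in configuration as drawn: 1 of 3 stereo elements differ; a stereocentre at a saturated ring carbon is drawn R in compound 3 and S in compound 4, which means the same atoms and bonds, with a stereocentre at a saturated ring carbon drawn R in compound 3 and S in compound 4.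

Going by the values given here, one measured step bears on this change: no change at the digits printed from compound 1 to compound 2 (within the scatter). The comparison rests on (the fact that compounds 1 and 2 differ only in the configuration as drawn), so it is the same kind of change, but it is a single pair and carries limited weight.

On that basis, no step beyond the scatter is expected in this assay, in either direction. The expected change is no change at the digits printed from compound 3 to compound 4 (within the scatter). The estimate for compound 4 is 100 ug/mL, with an expected range from 50 ug/mL to 200 ug/mL.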

Compound 4, half-maximal cytotoxic concentration: 100 ug/mL
Estimate against measurement, compound 4: no gap at the digits printed; the range from low to high includes it.
By their numbers in this assay, from the lowest: compounds 1, 2, 3 and 4 (each within the scatter of the next).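

In this assay, the change of drawn configuration at the saturated ring carbon now has a second reading, no change at the digits printed from compound 3 to compound 4 (within the scatter). This pair carries sulfur where compounds 1 and 2 carry oxygen, so the absence of a step seen for that change is no longer confined to a single pair. The pair is a clean test of configuration alone: the fact that compounds 3 and 4 differ only in the configuration as drawn

Going by these compounds alone, with only two pairs, this remains an observation about these four compounds, not a rule for the series. Still open, as far as these compounds go, is whether an amine or a carboxylic acid in place of the bromovinyl group would leave this assay where compound 4 stands at 100 ug/mL, and whether the other stereocentres tolerate inversion equally.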